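Chain length and amine on a cinnamanilide lipophilicity series

The source may report more compounds than this note shows. Statements on the series, on what has been measured and on what is new or still open speak of the compounds shown alone.

Compound 3 `COc1cc(/C=C/C(=O)Nc2ccccc2)ccc1OCCCCCCN1CCCC1` gives 1.76 in a physicochemical assay for lipophilicity, using the shake flask method, measured as octanol-water partition, at pH 7.4; on this read-out higher numbers stand for higher lipophilicity and lower numbers for lower lipophilicity. Its neighbours sit close by: compound 1 `COc1cc(/C=C/C(=O)Nc2ccccc2)ccc1OCCCCN(C)C` gives 1.57 and compound 2 `COc1cc(/C=C/C(=O)Nc2ccccc2)ccc1OCCCCN1CCCC1` gives 1.6, with a number 0.19 log units higher from compound 1 to compound 3 (within the scatter) and a number 0.16 log units higher from compound 2 to compound 3 (within the scatter). Compound 4 `CCN(CC)CCCCCCCCOc1ccc(/C=C/C(=O)Nc2ccccc2)cc1OC` is unmeasured; it differs from compound 3 by 2-(diethylamino)ethyl in place of pyrrolidin-1-yl on a saturated chain carbon, six bonds along the chain from an oxygen on an aromatic ring. Two earlier steps bear on this: exchanging the amine, a number 0.03 log units higher from compound 1 to compound 2 (within the scatter), and lengthening the chain, a number 0.16 log units higher from compound 2 to compound 3 (within the scatter). Both stayed within the scatter, so a step of similar small size upward, if any, is expected here, a number 0.19 log units higher from compound 3 to compound 4 (within the scatter). Compound 4 is therefore estimated at 1.95 in this assay, with a plausible range from 1.55 to 2.35.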

Compound 4, partition coefficient: 1.75
Beside the measured number, compound 4's estimate is 0.20 log units above it; the range from low to high includes it.
By their numbers in this assay, from the lowest: compounds 1, 2, 4 and 3 (each within the scatter of the next).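

In this assay, 2-(diethylamino)ethyl, with no ring, in place of pyrrolidin-1-yl, six bonds along the chain from an oxygen on an aromatic ring, gives a number 0.01 log units lower from compound 3 to compound 4 (within the scatter), so the open amine does not separate the two compounds on this read-out. The wider steps, a number 0.15 log units higher from compound 2 to compound 4 (within the scatter) and a number 0.18 log units higher from compound 1 to compound 4 (within the scatter), also stay within the scatter, leaving all four compounds unresolved. No measured evidence accounts for this result. From the compounds shown here alone, whether a morpholine or a piperidine in place of these amines, or a longer chain, would give a step beyond the scatter remains open.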